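The source may hold more compounds than are shown below. What is called first, only, known or untested is meant among the compounds shown, and "the series" means these compounds.

Measured so far:
compound 1, `COc1cc(NC(C)CCCNC(=O)NNC(=O)Nc2cc(C(F)(F)F)cc(C(F)(F)F)c2)c2ncccc2c1` — in a functional assay on NCI-H460 cells (Homo sapiens) for inhibition, read by MTT assay, with a stated time of 72 h (on this read-out higher numbers stand for weaker inhibition and lower numbers for stronger inhibition), compound 1 gives 18000 nM
compound 2, `COc1cc(NC(C)CCCNC(=O)NNC(=O)Nc2ccc(O)cc2)c2ncccc2c1` — in this assay compound 2 gives only a limit, > 100000 nM

Compound 2 therefore stands at a limit of this assay rather than at a number; its entry is the limit of > 100000 nM in this assay, at which 1 of the 2 values shown sits. Within the data shown here, compound 1 is the only compound of the two with an actual value, and that value itself is weak.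

Compound 3, `COc1cc(NC(C)CCCNC(=O)Nc2ccc(Br)cc2)c2ncccc2c1`, has not yet been measured in this assay. It is the second compound with one part of the chain on the shared core exchanged: 4-bromophenyl in place of ((4-hydroxyphenyl)carbamoyl)amino on an amide-type nitrogen. Among the measured compounds shown here, no step between two measured compounds is available for comparison, so the size of the step can only be guessed. Given that compound 2 sits at a limit, the step from compound 2 to compound 3 is expected to bring compound 3 back toward a measurable value, a shift beyond the scatter but of uncertain size. Compound 3 is expected to give about 30000 nM in this assay, within 8000 nM to 100000 nM, which means an expected step of an at least 3.3-fold lower number from compound 2 to compound 3 (0.52 log units; beyond the scatter).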

Compound 3, half-maximal inhibitory concentration: 30000 nM
For compound 3 middle estimate and measured number coincide at the digits printed, and the stated range covers the measured number.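

In this assay, 4-bromophenyl in place of ((4-hydroxyphenyl)carbamoyl)amino on an amide-type nitrogen gives an at least 3.3-fold lower number from compound 2 to compound 3 (0.52 log units; beyond the scatter) and shows that the change at this position can move a compound off the limit of the assay. With the aryl ring set directly on this nitrogen and the carbamoylamino part gone, compound 3 gives 30000 nM in this assay, an actual number, though still a high one. From the compounds shown here alone, compound 2 stands at a limit and not at a number, so the step is a bound and its true size stays unknown: the limit of > 100000 nM in this assay, at which 1 of the 3 values shown sits.

The exchange changes two things at once, the length of the chain and the substituent on the ring, and the compounds shown do not separate the part played by each; 4-hydroxyphenyl directly on the same nitrogen, or 4-bromophenyl with the carbamoylamino part kept, would do so. Also open, going by these compounds, is how a ring bearing an amine or a carboxylic acid in place of the bromine would read on this nitrogen.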